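This account rests on a few compounds, and the source may have more. Where it says the series, first, only, none or still open, it means among the compounds named here.

Measured compounds:
Compound 1, `COC(=O)/C=C/c1cccc(N(Cc2ccc(/C=C/c3ccccn3)cc2)C(=O)C(C)C)c1`, gives 310 nM in an assay on isolated protein with Bile acid receptor (Homo sapiens) as the target; a higher number here means that more compound is needed for the effect, a lower number that less compound is needed.
Compound 2, `COC(=O)/C=C/c1cccc(N(Cc2ccc(-c3ccc(OC)cc3)cc2)C(=O)C(C)C)c1`, gives 97 nM in this assay.
Compound 3, `COC(=O)/C=C/c1cccc(N(Cc2ccc(-c3ccc(C)cc3)cc2)C(=O)C(C)C)c1`, gives 118 nM in this assay.

Compound 3 stands second highest of the three numbers in this assay. Its nearest neighbour is compound 2, and the step of a 1.2-fold higher number from compound 2 to compound 3 (0.09 log units; within the scatter) lies within the scatter, so the two cannot be ordered. Its furthest neighbour is compound 1, and the step of a 2.6-fold lower number from compound 1 to compound 3 (0.42 log units; beyond the scatter) is beyond the scatter, as is the parallel step a 3.2-fold lower number from compound 1 to compound 2 (0.50 log units; beyond the scatter).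

Compound 4, `COC(=O)/C=C/c1cccc(N(Cc2ccc(-c3ccc(OC(F)(F)F)cc3)cc2)C(=O)C(C)C)c1`, differs from compound 3 in one place: trifluoromethoxy in place of methyl on an aromatic carbon. For the measured compounds named here, the only measured step that touches this position is the step of a 1.2-fold higher number from compound 2 to compound 3 (0.09 log units; within the scatter), where methoxy and methyl gave numbers within the scatter of each other. Going by the values given here, no measured compound carries trifluoromethoxy, so nothing in the data shows how this particular group behaves. On that basis compound 4 is expected to stay close to compounds 2 and 3, with a step of a 1.2-fold lower number from compound 3 to compound 4 (0.07 log units; within the scatter) that is not expected to exceed the scatter, and any direction uncertain.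

Compound 4 is therefore estimated at 100 nM in this assay, with a range from 40 nM to 250 nM.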

Compound 4, half-maximal effective concentration: 219 nM
Compound 4: middle estimate off by 2.2-fold (0.34 log units), on the low side, within the range that was stated.
By their numbers in this assay, from the lowest: compounds 2, 3, 4 and 1 (each within the scatter of the next, the first and the last beyond it).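

At this position, on an aromatic carbon para to a large group, the earlier compounds had shown only that methoxy and methyl could not be told apart, whereas in this assay the step of a 2.3-fold higher number from compound 2 to compound 4 (0.35 log units; beyond the scatter) is the first change of a substituent here to go beyond the scatter, and it comes from trifluoromethyl in place of methyl on the oxygen. The position is thus not wholly indifferent to the group it carries, although the effect is modest: the step of a 1.9-fold higher number from compound 3 to compound 4 (0.27 log units; within the scatter) stays within the scatter, so compound 4 cannot be ordered against compound 3, and the step of a 1.4-fold lower number from compound 1 to compound 4 (0.15 log units; within the scatter) is also within the scatter, which leaves compound 4 no clearer of the pyridinyl-ethenyl compound than of the methyl compound. Nothing available bears on why the trifluoromethoxy compound separates from the methoxy compound alone.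

From the compounds shown here alone, it remains open how a trifluoromethyl group placed directly on the ring, a chlorine or an amine would behave at this position. Also open, going by these compounds, is whether the same step would appear if the methyl ester of the shared core gave way to a carboxylic acid.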